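Adding a Second Chloro to Compound 3

The source may hold more compounds than are shown below. What is called first, only, known or untested is meant among the compounds shown, and "the series" means these compounds.

Of the compounds shown here, three have been measured in a functional assay on OVCAR-5 cells (Homo sapiens) for inhibition, read by sulforhodamine B assay, with a stated time of 48 h; on this read-out lower numbers stand for stronger inhibition of growth and higher numbers for weaker inhibition of growth. Compound 1 `COc1cc(C(=O)N2CCN(C=O)C2=S)cc(OC)c1OC` gives 48500 nM in this assay. Compound 2 `O=CN1CCN(C(=O)c2ccco2)C1=S` gives 18000 nM in this assay, and compound 3 `O=CN1CCN(c2ccc(Cl)cc2)C1=S` gives 17400 nM. Compound 3 shows the lowest of the three numbers; its value and that of compound 2 lie within the scatter of each other, so no order can be read between them, while the number for compound 1 stands beyond the scatter above that of compound 3.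

Compound 4 `O=CN1CCN(c2ccc(Cl)c(Cl)c2)C1=S` has not yet been measured in this assay. It differs from compound 3 in one place: chloro in place of hydrogen on an aromatic carbon. For the measured compounds named here, no pair of measured compounds shows this same change, so the size of the step cannot be taken from the data and must be judged from the three numbers alone, all of which sit in a weak range. The expected step is a 1.5-fold lower number from compound 3 to compound 4 (0.16 log units; within the scatter), a small gain in inhibition rather than no change, though the uncertainty is wide. For compound 4 the expected value in this assay is 12000 nM, with a range from 4000 nM to 40000 nM.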

Compound 4, concentration for 50% growth inhibition: 16900 nM
Beside the measured number, compound 4's estimate is 1.4-fold (0.15 log units) below it; the range from low to high includes it.
By their numbers in this assay, from the lowest: compounds 4, 3 and 2 (each within the scatter of the next); then compound 1.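

For the compounds shown here, the step of a 1.0-fold lower number from compound 3 to compound 4 (0.01 log units; within the scatter) in this assay is the first single-place change that can be read, and it shows that chloro in place of hydrogen at this position, ortho to a chloro group and meta to a group of 8 heavy atoms, brings no change that can be told from repeat measurement. The earlier compounds shown here could say nothing about this position, whereas this pair shows that the aromatic carbon can carry a second chloro while the number for compound 4, 16900 nM, stays in the same weak range as that of compound 3, 17400 nM. No measurement at hand bears on why the second chloro leaves the number where it is.

The compounds shown leave open whether a different group on this carbon, such as a methoxy group, an amine or a carboxylic acid, would move the number beyond the scatter. They also leave open whether the same chloro would behave alike without the first chloro, or whether replacing the formyl group on the shared core would bring a clearer gain in inhibition of growth.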